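Cyclopentyl in place of ethyl on the shared core

This account rests on a few compounds, and the source may have more. Where it says the series, first, only, none or still open, it means among the compounds named here.

Among the measured compounds shown here, in a functional assay on HCT-116 cells (Homo sapiens) for cytotoxicity, with a stated time of 48 h (on this read-out higher numbers stand for weaker inhibition of growth and lower numbers for stronger inhibition of growth), compound 3 `CCc1cc(-c2cc(N3C[C@H](O)[C@@H](O)C3)ccc2O)nc(N)n1` gives 1000 nM, the only true number in the set. Compound 1 `CN(C)c1cc(-c2cc(N3C[C@H](O)[C@@H](O)C3)ccc2O)nc(N)n1` reads > 10000 nM, which is a limit. Compound 2 `Nc1nc(-c2cc(N3C[C@H](O)[C@@H](O)C3)ccc2O)cc(C2CCNCC2)n1` reads > 10000 nM, also a limit.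

Compound 4 `Nc1nc(-c2cc(N3C[C@H](O)[C@@H](O)C3)ccc2O)cc(C2CCCC2)n1` carries cyclopentyl in place of ethyl on an aromatic carbon. Two measured steps at this carbon bear on the change: an at least 10-fold lower number from compound 1 to compound 3 (1.00 log units; beyond the scatter) and an at least 10-fold lower number from compound 2 to compound 3 (1.00 log units; beyond the scatter). The second is the closer guide, since compound 2 also has a ring there, although its piperidin-4-yl differs from cyclopentyl. The expected step is a 2.0-fold higher number from compound 3 to compound 4 (0.30 log units; within the scatter), small and leaning toward a higher number. For compound 4 the estimate is 2000 nM, with an expected range of 500 nM to 8000 nM.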

Compound 4, concentration for 50% growth inhibition: 400 nM
Beside the measured number, compound 4's estimate is 5.0-fold (0.70 log units) above it, outside the stated range (below it).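

In this assay, cyclopentyl in place of ethyl gives a 2.5-fold lower number from compound 3 to compound 4 (0.40 log units; beyond the scatter), so the larger all-carbon ring at this aromatic carbon improves on ethyl rather than costing growth inhibition. Cyclopentyl in place of piperidin-4-yl gives an at least 25-fold lower number from compound 2 to compound 4 (1.39 log units; beyond the scatter), and in place of dimethylamino it gives an at least 25-fold lower number from compound 1 to compound 4 (1.39 log units; beyond the scatter), so a ring as such does not set the read-out here. Both of these larger steps start from a limit, not a number: the limit of > 10000 nM in this assay, at which 2 of the 4 values shown sit.

From the compounds shown here alone, whether cyclohexyl or phenyl at this carbon would lower the number further stays open. So does whether a ring oxygen, as in tetrahydropyran-4-yl, would be accepted.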